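Moving the Bromine Around the Benzyl Ring

A few compounds are considered here, and "the series" means these few. Any claim that something is new, unique, unknown or untested is made for them only; others in the source may bear on it.

Among the compounds with values here, compound 3 `O=C(/C=C/c1ccc(OCc2cn(Cc3cccc(Br)c3)nn2)cc1)c1ccc([N+](=O)[O-])cc1` gives 13% in a functional assay on HepG2 cells (Homo sapiens) for inhibition, read by MTT assay, with a stated time of 48 h, tested at 10 uM (a higher number here means more inhibition of growth at the concentration tested, a lower number less inhibition of growth), the lowest of the three numbers measured so far. Compound 1 `O=C(/C=C/c1ccc(OCc2cn(Cc3ccc(Br)cc3)nn2)cc1)c1ccc(Br)cc1` gives 22%, which lies within the scatter of compound 3, while compound 2 `O=C(/C=C/c1ccc(OCc2cn(Cc3ccccc3Br)nn2)cc1)c1ccc([N+](=O)[O-])cc1` gives 32%. Within the data shown here, the one step that changes a single feature, a number 19 percentage points lower from compound 2 to compound 3 (beyond the scatter), concerns where the bromine sits on the benzyl group. Compound 4 `O=C(/C=C/c1ccc(OCc2cn(Cc3ccc(Br)cc3)nn2)cc1)c1ccc([N+](=O)[O-])cc1` differs from compound 3 by 4-bromophenyl in place of 3-bromophenyl on a saturated chain carbon bound to an aromatic nitrogen. Among the measured compounds shown here, no measured pair tests this exact exchange; compound 1 also carries 4-bromophenyl but differs elsewhere, and its value sits within the scatter of compound 3. The expected step of a number 7 percentage points higher from compound 3 to compound 4 (within the scatter) is therefore small, with no clear direction beyond the scatter. Compound 4 is estimated at 20%, between 8% and 34%.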

Compound 4, percent growth inhibition at one concentration: 21%
For compound 4 the middle estimate is 1 percentage points below the measured one; measured number inside the range.
By their numbers in this assay, from the lowest: compounds 3, 4, 1 and 2 (each within the scatter of the next, the first and the last beyond it).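

With a number 8 percentage points higher from compound 3 to compound 4 (within the scatter) the 4-bromophenyl and 3-bromophenyl groups cannot be told apart in this assay on this saturated chain carbon. Only 2-bromophenyl stands out: a number 11 percentage points lower from compound 2 to compound 4 (beyond the scatter) adds a second step beyond the scatter to the earlier one. Nitro in place of bromo on an aromatic carbon, seen for the first time as a single change, gives a number 1 percentage points lower from compound 1 to compound 4 (within the scatter) and so no readable difference. No evidence is available that bears on these results. From the compounds shown here alone, whether 2-bromophenyl keeps its higher number with bromo in place of nitro remains open. So does the effect of a methoxy group or an amine in place of the bromine on the benzyl ring.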